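Enol ether alkynoates: trimming the saturated chain carbon substituent

The source may report more compounds than this note shows. Statements on the series, on what has been measured and on what is new or still open speak of the compounds shown alone.

Compound 2 `COC(=O)C#CC(CC(C)C)O/C=C/C(=O)OC` gives 330 nM in a functional assay on HBL-100 cells (Homo sapiens) for antiproliferative activity, read by sulforhodamine B assay, with a stated time of 48 h (on this read-out lower numbers stand for stronger inhibition of growth and higher numbers for weaker inhibition of growth), the lowest of the two numbers at hand. Compound 3 `Cc1ccc(S(=O)(=O)C#CC(O/C=C/S(=O)(=O)c2ccc(C)cc2)C(C)C)cc1` gives 3800 nM in this assay, a gap from compound 2 that is beyond the scatter. Compound 1 `C#CCO/C=C/C(=O)OC` reaches only a limit in this assay, > 100000 nM, and no number.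

Compound 4 `CCC(C#CC(=O)OC)O/C=C/C(=O)OC` differs from compound 2 by methyl in place of isopropyl on a saturated chain carbon, two bonds along the chain from an oxygen on an unsaturated carbon and a triple-bonded carbon. Going by the values given here, no measured pair isolates this change; compound 3 differs from compound 2 in several places at once, so its gap says nothing about this step alone. Resting on the value of compound 2 alone, a small step toward a higher number is expected, a 1.8-fold higher number from compound 2 to compound 4 (0.26 log units; within the scatter), within or just beyond the scatter. Compound 4 is therefore estimated at 600 nM, with a range from 200 nM to 2000 nM.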

Compound 4, concentration for 50% growth inhibition: 320 nM
For compound 4 the middle estimate is 1.9-fold (0.27 log units) above the measured one; measured number inside the range.
By their numbers in this assay, from the lowest: compounds 4 and 2 (each within the scatter of the next); then compound 3. At a limit, above all of these: compound 1.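

In this assay, going by these compounds alone, methyl in place of isopropyl on this saturated chain carbon gives a 1.0-fold lower number from compound 2 to compound 4 (0.01 log units; within the scatter) and is the first step to isolate a single place. The read-out does not separate the two groups here, so the larger branched group is not required for a value of this order. No measurement shown accounts for this result.

Going by these compounds, what a hydrogen, a longer chain or a phenyl group on this carbon would give remains open. Compound 1 and compound 3 each differ from compound 2 in several places, so neither settles that question.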